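Cytotoxicity of a triazole series on HEK293 cells

The compounds below may be only part of what the source reports. "The series", "measured", "known", "first", "only" and "open" are said of these compounds alone.

Measured compounds:
compound 1 `COc1nc2ccc(Br)cc2cc1C(c1ccccc1)n1cc(-c2ccc(Br)cc2)nn1`: 6.28%
compound 2 `COc1nc2ccc(Br)cc2cc1C(c1ccccc1)n1cc(-c2cccc(F)c2)nn1`: 6.84%
compound 3 `COc1nc2ccc(Br)cc2cc1C(c1ccccc1)n1cc(-c2ccc(OC(F)(F)F)cc2)nn1`: 5.8%

In an ADME assay on HEK293 cells (Homo sapiens) for cytotoxicity, read by sulforhodamine B assay, with a stated time of 48 h, tested at 10 uM (on this read-out higher numbers stand for more inhibition at the one concentration tested (going by the name of the read-out) and lower numbers for less inhibition), compound 1 gives 6.28%, compound 2 gives 6.84% and compound 3 gives 5.8%. The three numbers sit close together: the step is a number 0.6 percentage points higher from compound 1 to compound 2 (within the scatter), then a number 0.5 percentage points lower from compound 1 to compound 3 (within the scatter), and a number 1 percentage points lower from compound 2 to compound 3 (within the scatter). Compound 3 therefore stands at the low end of a group of three figures that cannot be told apart in this assay.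

Compound 4 `COc1nc2ccc(Br)cc2cc1C(c1ccccc1)n1cc(CCCCCO)nn1` differs from compound 3 by 5-hydroxypentyl in place of 4-(trifluoromethoxy)phenyl on an aromatic carbon. Among the measured compounds shown here, none of the measured steps bears directly on this change: each of them swaps one six-membered aromatic ring for another on the same carbon of the five-membered ring, and each stays within the scatter. For the measured compounds named here, a 5-hydroxypentyl chain in that place has no precedent among the three measured compounds, so the expectation rests only on the observation that every variation made so far at this position left the read-out unchanged.

On that basis compound 4 is expected to show a number 0.2 percentage points higher from compound 3 to compound 4 (within the scatter), that is, no step beyond the scatter. The estimate for compound 4 in this assay is 6%, with a range from -4% to 16%.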

Compound 4, a percentage reported as inhibition, at one concentration (the size of the read-out at that concentration, not a potency): 7.96%
Estimate against measurement, compound 4: 2 percentage points below; the measured number falls inside the stated range.
By their numbers in this assay, from the lowest: compounds 3, 1, 2 and 4 (each within the scatter of the next).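

In this assay, the 5-hydroxypentyl chain of compound 4 has no ring and carries a hydrogen-bond donor, unlike the aromatic groups it replaces, and the steps to it are a number 2.2 percentage points higher from compound 3 to compound 4 (within the scatter), a number 1.1 percentage points higher from compound 2 to compound 4 (within the scatter) and a number 1.7 percentage points higher from compound 1 to compound 4 (within the scatter). Among the compounds shown here, the earlier compounds showed only that one six-membered aromatic ring could be swapped for another on this carbon of the five-membered ring without a step beyond the scatter, whereas compound 4 shows the same for a change to an open chain with no aromatic ring at all. Nothing available explains why the read-out stays within the scatter across this change.

The compounds shown leave open whether an amine or a carboxylic acid in place of the hydroxy group of the 5-hydroxypentyl chain, or a longer chain, would also stay within the scatter of these figures. They also leave open how any of the four compounds would read at another concentration, and whether a change elsewhere on the shared core would give a step beyond the scatter.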